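Nitro in Place of Nitrile: An Expected Loss of Potency

A few compounds are considered here, and "the series" means these few. Any claim that something is new, unique, unknown or untested is made for them only; others in the source may bear on it.

Compound 3 `CC(CS(=O)(=O)c1ccc(C(F)(F)F)cc1)C(=O)Nc1ccc(C#N)cc1C(F)(F)F` holds the second highest of the three numbers in a functional assay on LNCaP cells (Homo sapiens) for antiproliferative activity, read by MTT assay, with a stated time of 96 h (a lower number here means a stronger inhibitor, a higher number a weaker inhibitor), where compound 3 gives 28800 nM. Compound 1 `CC(CSc1cc(C(F)(F)F)cc(C(F)(F)F)c1)C(=O)Nc1ccc(C#N)cc1C(F)(F)F` gives 4570 nM and compound 2 `CC(CSc1cc(C(F)(F)F)cc(C(F)(F)F)c1)C(=O)Nc1ccc([N+](=O)[O-])cc1C(F)(F)F` gives 43700 nM in this assay, so compound 3 lies within the scatter of compound 2 and well above compound 1. Compound 4 `CC(CS(=O)(=O)c1ccc(C(F)(F)F)cc1)C(=O)Nc1ccc([N+](=O)[O-])cc1C(F)(F)F` differs from compound 3 by nitro in place of cyano on an aromatic carbon. The same exchange has been seen once before on the core of compound 1: a 9.6-fold higher number from compound 1 to compound 2 (0.98 log units; beyond the scatter). Should that step carry over, compound 4 is expected to show a clearly higher number, a step of a 6.9-fold higher number from compound 3 to compound 4 (0.84 log units; beyond the scatter). Compound 4 is therefore estimated at 200000 nM in this assay, with a likely range from 60000 nM to 600000 nM and a fair chance that only a limit is reported.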

Compound 4, half-maximal inhibitory concentration: 26300 nM
Compound 4: middle estimate off by 7.6-fold (0.88 log units), on the high side; the measured number lies below the stated range.
By their numbers in this assay, from the lowest: compound 1; then compounds 4, 3 and 2 (each within the scatter of the next).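

In this assay, nitro in place of cyano on this aromatic carbon gives a 1.1-fold lower number from compound 3 to compound 4 (0.04 log units; within the scatter). The exchange therefore carries no fixed cost at this position, and the size of its step depends on the core that carries it: the same change on two cores in this assay, a 9.6-fold higher number (0.98 log units; beyond the scatter) from compound 1 to compound 2 and a 1.1-fold lower number (0.04 log units; within the scatter) from compound 3 to compound 4, 10-fold (1.02 log units) apart, beyond the scatter of two such steps

The two cores differ in more than one place, so the compounds shown do not tell which of those differences sets the size of the step. From the compounds shown here alone, whether an amine or a carboxylic acid on this carbon would follow the pattern of either core also remains open.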